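A few compounds are considered here, and "the series" means these few. Any claim that something is new, unique, unknown or untested is made for them only; others in the source may bear on it.

Measured in a functional assay on KB cells (Homo sapiens) for inhibition, with a stated time of 72 h; on this read-out lower numbers stand for stronger inhibition and higher numbers for weaker inhibition:
- compound 1 `CC(=O)Oc1cc2oc(-c3ccccc3)cc(=O)c2c(OC(C)=O)c1OC(C)=O`: 14500 nM
- compound 2 `COc1cc2oc(-c3ccccc3)cc(=O)c2c(OC)c1OC(C)=O`: 85500 nM
- compound 3 `CC(=O)Oc1cc2oc(-c3ccccc3)cc(=O)c2c(OCc2ccccc2)c1OC(C)=O`: 11300 nM

Compound 1 lies within the scatter of compound 3, and its number is clearly lower than that of compound 2. Compound 4 `CC(=O)Oc1c(OCc2ccccc2)cc2oc(-c3ccccc3)cc(=O)c2c1OC(C)=O` has not yet been measured. It keeps the core of compound 1 and carries this change: benzyl in place of acetyl on an oxygen on an aromatic ring. In words, benzyl takes the place of acetyl on an oxygen on an aromatic ring. Within the data shown here, the one measured step of this kind, a 1.3-fold lower number from compound 1 to compound 3 (0.11 log units; within the scatter), sits on another oxygen, so it is only a guide. No step beyond the scatter is therefore expected in this assay. The expected step is a 1.1-fold lower number from compound 1 to compound 4 (0.05 log units; within the scatter). The estimated value for compound 4 is 13000 nM, with an expected range of 5000 nM to 35000 nM.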

Compound 4, half-maximal inhibitory concentration: 13400 nM
The estimate for compound 4 lay 1.0-fold (0.01 log units) below the measured number; the range from low to high includes it.
By their numbers in this assay, from the lowest: compounds 3, 4 and 1 (each within the scatter of the next); then compound 2.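

Putting benzyl in place of acetyl on this oxygen gives a 1.1-fold lower number from compound 1 to compound 4 (0.03 log units; within the scatter), so in this assay this position accepts the acetoxy to benzyloxy change without a step beyond the scatter. The same change on another oxygen gave a 1.3-fold lower number from compound 1 to compound 3 (0.11 log units; within the scatter), so the two oxygens now read alike for this swap. No measurement here explains why the number holds.

As far as these compounds go, it remains open whether a chain ending in an amine or a carboxylic acid on this oxygen would shift the number, and whether benzyl on the remaining acetylated oxygen would read the same.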